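The source may hold more compounds than are shown below. What is called first, only, known or untested is meant among the compounds shown, and "the series" means these compounds.

Compound 2 `Cc1cnc(NCC2(c3ccc(F)cc3)CC2)c(=O)n1CC(=O)NCc1ccc2[nH]nc(N)c2c1` gives the lowest of the three numbers in a physicochemical assay for acid dissociation, at 3.6; compound 1 `Cc1ccc(NS(=O)(=O)Cc2ccc(Br)cc2)c(=O)n1CC(=O)NCc1ccc2c(N)noc2c1` gives 8.6 and compound 3 `Cc1cnc(NCC2(c3ccc(F)cc3)CC2)c(=O)n1CC(=O)NCc1ccc2c(N)noc2c1` gives 8.6. Among the measured compounds shown here, the one measured step, a number 5.00 log units higher from compound 2 to compound 3 (beyond the scatter), concerns a different part of the molecule. Compound 4 `COc1ccc(C2(CNc3ncc(C)n(CC(=O)NCc4ccc5[nH]nc(N)c5c4)c3=O)CC2)cc1` differs from compound 2 by methoxy in place of fluoro on an aromatic carbon. For the measured compounds named here, no measured step touches this phenyl ring, so nothing here speaks for a shift; because compound 2 gives 3.6, compound 4 is expected to stay within the scatter of compound 2. The estimated step is no change at the digits printed from compound 2 to compound 4 (within the scatter). For compound 4 the estimate in this assay is 3.6, with a range from 3.2 to 4.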

Compound 4, acid dissociation constant: 3.6
Beside the measured number, compound 4's estimate shows no gap at the digits printed; the range from low to high includes it.
By their numbers in this assay, from the lowest: compounds 2 and 4 (each within the scatter of the next); then compounds 1 and 3 (each within the scatter of the next).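

Methoxy in place of fluoro on this aromatic carbon, para to a large group, gives in this assay no change at the digits printed from compound 2 to compound 4 (within the scatter). This is the first step shown at the 4-fluorophenyl ring, and the change of group there leaves the read-out in place, unlike the step in the other part of the molecule. Nothing available explains this result. As far as these compounds go, whether an amine or a carboxylic acid at this position would also leave the number in place remains open. So does whether methoxy for fluoro reads the same on compound 3.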